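The compounds below may be only part of what the source reports. "The series", "measured", "known", "first", "only" and "open" are said of these compounds alone.

Compound 1 `C=C1CC[C@H]2C(C)(C)[C@H](O)CC[C@]2(C)[C@H]1C[C@]12O[C@H]1[C@H](O)C(COC(=O)[C@H](O)[C@H](C)O)=CC2=O` gives 21600 nM
Compound 2 `C=C1CC[C@H]2C(C)(C)[C@H](O)CC[C@]2(C)[C@H]1C[C@]12O[C@H]1C(=O)C(COC(=O)C[C@H](C)O)=CC2=O` gives 1300 nM
Compound 3 `C=C1CC[C@H]2C(C)(C)[C@H](O)CC[C@]2(C)[C@H]1C[C@]12O[C@H]1[C@H](O)C(CO)=CC2=O` gives 25300 nM

In a functional assay on HL-60 cells (Homo sapiens) for inhibition, read by MTT assay, with a stated time of 2 days (a lower number here means a stronger inhibitor, a higher number a weaker inhibitor), compound 2 at 1300 nM holds the lowest of the three numbers. Compound 4 `C=C1CC[C@H]2C(C)(C)[C@H](O)CC[C@]2(C)[C@H]1C[C@]12O[C@H]1C(=O)C(CO)=CC2=O` differs from compound 2 by a hydrogen atom in place of a group of 6 heavy atoms (4 carbon, 2 oxygen; no ring), on an oxygen on a saturated carbon and has not been measured. Within the data shown here, the only measured step of this kind is a 1.2-fold higher number from compound 1 to compound 3 (0.07 log units; within the scatter) on the core of compound 1, where the group that leaves is not the same. With that step as the guide, no step beyond the scatter is expected in this assay here, though the core of compound 2 differs from that of compound 1, so the range is kept wide. For compound 4 the expected value is 1500 nM within an estimated range from 500 nM to 5000 nM as a working figure. The expected change is a 1.2-fold higher number from compound 2 to compound 4 (0.06 log units; within the scatter) in this estimate.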

Compound 4, half-maximal inhibitory concentration: 300 nM
For compound 4 the middle estimate is 5.0-fold (0.70 log units) above the measured one; the whole stated range lies above it.
By their numbers in this assay, from the lowest: compound 4; then compound 2; then compounds 1 and 3 (each within the scatter of the next).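

In this assay the ester group on this oxygen is not needed for the lower number, since the change to hydrogen gives a 4.3-fold lower number from compound 2 to compound 4 (0.64 log units; beyond the scatter) and the free hydroxyl carries more activity on the core of compound 2. The step of the same kind on the core of compound 1 gives a 1.2-fold higher number from compound 1 to compound 3 (0.07 log units; within the scatter) and stays within the scatter, so the size of this change differs between the two pairs, whose cores and leaving groups both differ. No available evidence bears on the difference between the two steps.

The compounds shown leave open how a simple acetate or a longer chain ester on this oxygen would read on the core of compound 2. On these data alone, an amine in place of this hydroxyl also remains open.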